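Acetyl to propanoyl on a weakly active amide

A few compounds are considered here, and "the series" means these few. Any claim that something is new, unique, unknown or untested is made for them only; others in the source may bear on it.

Measured compounds:
compound 1 `CC(=O)N1c2ccccc2CCC1C(=O)Nc1cc(C(F)(F)F)cc(C(F)(F)F)c1` — > 70000 nM (a limit of the assay, not a number)
compound 2 `O=C(Nc1ccccc1C(F)(F)F)C1CCc2ccccc2N1C(=O)c1ccc(Cl)cc1` — 551 nM

In a functional assay on NUGC-3 cells (Homo sapiens) for cytotoxicity, read by sulforhodamine B assay, with a stated time of 72 h (a higher number here means a weaker inhibitor of growth, a lower number a stronger inhibitor of growth), compound 1 reaches only > 70000 nM, which is a limit of the assay and not a measured number. That limit is recorded as the limit of > 70000 nM in this assay, at which 1 of the 2 values shown sits. For the measured compounds named here, compound 2, with a different amide on the core nitrogen and a different aniline, gives 551 nM in this assay; no single-change step joins it to compound 1, so the two values are simply stated side by side.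

Compound 3 `CCC(=O)N1c2ccccc2CCC1C(=O)Nc1cc(C(F)(F)F)cc(C(F)(F)F)c1` is not yet measured. It differs from compound 1 by methyl in place of hydrogen on a saturated chain carbon bound to a carbonyl carbon, that is, the acetyl on the core nitrogen becomes a propanoyl. Going by the values given here, no measured pair in this set changes that group alone, so there is no step to lean on. Since compound 1 sits at the limit (the limit of > 70000 nM in this assay, at which 1 of the 2 values shown sits), a step of a number no higher from compound 1 to compound 3 (the limit leaves the size open) is expected, meaning no change beyond the scatter in either direction. Compound 3 is therefore estimated at 70000 nM, with a range from 20000 nM to 200000 nM, most likely reported again only as a limit.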

Compound 3, concentration for 50% growth inhibition: 7220 nM
The estimate for compound 3 lay 9.7-fold (0.99 log units) above the measured number, outside the stated range (below it).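

In this assay, the change from acetyl to propanoyl, methyl in place of hydrogen on a saturated chain carbon bound to a carbonyl carbon, gives an at least 9.6-fold lower number from compound 1 to compound 3 (0.98 log units; beyond the scatter). For the compounds shown here, this is the first single-change step in the set, and it shows that this position is not indifferent: with the rest of the molecule unchanged, one added methyl is enough to take the number beyond the scatter and turn a limit into a measured value. The full size of the step stays open, because compound 1 carries only a limit of the assay and not a number: the limit of > 70000 nM in this assay, at which 1 of the 3 values shown sits.

The compounds shown leave open whether a longer chain such as butanoyl, or a hydroxyl group or an amine on that same chain, would lower the number further or raise it again. Compound 2 differs from compound 3 in more than one place, and it does not tell whether the step from acetyl to propanoyl would carry over to another aniline.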